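Inverting Two Ring Stereocentres in a Carboxylic Acid

A few compounds are considered here, and "the series" means these few. Any claim that something is new, unique, unknown or untested is made for them only; others in the source may bear on it.

Of the compounds shown here, three have been measured in a functional assay on SF-539 cells (Homo sapiens) for inhibition; on this read-out higher numbers stand for weaker inhibition of growth and lower numbers for stronger inhibition of growth. Compound 1 `C=C1CCC[C@H]2[C@](C)(CCC(C)=O)[C@@H](C)CC[C@]12C` returns only a limit of > 15000 nM in this assay. Compound 2 `C=C1CCCC(C)(C)C1CC[C@]1(C)CC[C@H]([C@@H](C)C(=O)OC)OO1` gives 6250 nM in this assay, and compound 3 `C=C1CCCC(C)(C)C1CC[C@@]1(C)CC[C@H]([C@@H](C)C(=O)O)OO1` gives 3280 nM. Compound 3 sits at the lower of the two numbers, though its gap to compound 2 lies within the scatter, so the two cannot be ranked. Compound 4 `C=C1CCCC(C)(C)C1CC[C@]1(C)CC[C@@H]([C@@H](C)C(=O)O)OO1` is the compound still to be measured. It differs from compound 3 as follows: the two compounds have the same atoms and bonds; at least one stereo element is drawn with a configuration in one of them and without one in the other: 2 of 4 stereo elements differ; a stereocentre at a saturated ring carbon is drawn S in compound 3 and R in compound 4; a stereocentre at a saturated ring carbon is drawn R in compound 3 and S in compound 4. Within the data shown here, no measured pair here shows what such a change does in this assay, so the expected step of a 1.1-fold higher number from compound 3 to compound 4 (0.03 log units; within the scatter) is taken as none beyond the scatter. Compound 4 is therefore expected to give about 3500 nM, with a likely range from 1000 nM to 12000 nM.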

Compound 4, concentration for 50% growth inhibition: > 10000 nM
Compound 4: a limit, no number; the forecaster's own chance of this, stated with the estimate: 10%; middle value at least 2.8-fold (0.45 log units) away from the limit.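

In this assay, inverting the two ring stereocentres while keeping every atom and bond gives an at least 3.0-fold higher number from compound 3 to compound 4 (0.48 log units; beyond the scatter). Among these compounds, no earlier pair could show this: for this carboxylic acid, the spatial arrangement at these ring carbons alone can shift growth inhibition beyond the scatter. Compound 4 returns a limit, not a number: the limit of > 10000 nM in this assay, at which 1 of the 4 values shown sits.

Which of the two stereocentres carries the change stays open, with both inverted together here. Also open, as far as these compounds go, is whether the same inversion would act alike on the methyl ester or on an amide in place of the carboxylic acid.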